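Swapping a nitrophenyl for a dichlorophenyl on the carbonyl

This account rests on a few compounds, and the source may have more. Where it says the series, first, only, none or still open, it means among the compounds named here.

Within the data shown here, compound 1 `O=C1c2ccccc2C(=O)N1CCOC(=S)N(C(=O)c1cccc([N+](=O)[O-])c1)c1ccc(Cl)cc1` has the lower of the two numbers so far in an ADME assay on MT4 cells (Homo sapiens) for cytotoxicity, read by MTT assay (on this read-out lower numbers stand for higher toxicity in this test and higher numbers for lower toxicity in this test), giving 18000 nM. Compound 2 `Cc1ccc(N(C(=O)c2ccccc2[N+](=O)[O-])C(=S)OCCN2C(=O)c3ccccc3C2=O)cc1`, a differently built relative, gives 100000 nM in this assay, a gap beyond the usual scatter. Compound 3 `O=C1c2ccccc2C(=O)N1CCOC(=S)N(C(=O)c1ccc(Cl)c(Cl)c1)c1ccc(Cl)cc1`, not yet measured, differs from compound 1 in one place: 3,4-dichlorophenyl in place of 3-nitrophenyl on a carbonyl carbon. Among the measured compounds shown here, no measured pair shows this kind of change, so only a small shift is expected, from compound 1 to compound 3 of a 1.5-fold lower number from compound 1 to compound 3 (0.18 log units; within the scatter), within or near the scatter. Compound 3 is expected to give about 12000 nM, with a likely range from 4000 nM to 40000 nM.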

Compound 3, half-maximal cytotoxic concentration: 35000 nM
Compound 3: the middle estimate sits 2.9-fold (0.46 log units) below what was measured, and the stated range covers the measured number.
By their numbers in this assay, from the lowest: compounds 1 and 3 (each within the scatter of the next); then compound 2.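

At this position on the carbonyl carbon, 3,4-dichlorophenyl can replace 3-nitrophenyl without a clear change in this assay, as the step is a 1.9-fold higher number from compound 1 to compound 3 (0.29 log units; within the scatter) and stays within the scatter. For this pair, the hydrogen-bond acceptors of the 3-nitrophenyl group are therefore not needed to keep the number at this level. Nothing measured here explains the result.

On these data alone, whether an amine or a carboxylic acid at this place would move the number beyond the scatter remains open. So does whether this swap would behave the same way on a different core.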